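The source may hold more compounds than are shown below. What is called first, only, known or untested is meant among the compounds shown, and "the series" means these compounds.

Compound 1 `Cc1ccc(-n2nccn2)c(C(=O)N2C[C@H](C#Cc3ccc(CO)nc3)CC[C@H]2C)c1`: 150 nM
Compound 2 `Cc1ccc(-n2nccn2)c(C(=O)N2C[C@H](/C=C/c3ccc(F)cn3)CC[C@H]2C)c1`: 3 nM
Compound 3 `Cc1ccc(-n2nccn2)c(C(=O)N2C[C@H](C#Cc3cncc(CO)c3)CC[C@H]2C)c1`: 32 nM

These numbers come from an assay on cells for binding affinity to Orexin receptor type 2 (Homo sapiens), read by radioligand binding; a lower number here means a stronger inhibitor, a higher number a weaker inhibitor. Among the three, compound 3 stands second highest: compound 1 sits above it, since a 4.7-fold lower number from compound 1 to compound 3 (0.67 log units; beyond the scatter), and compound 2 sits well below it, since an 11-fold higher number from compound 2 to compound 3 (1.03 log units; beyond the scatter). Compound 4 `Cc1ccc(-n2nccn2)c(C(=O)N2C[C@H](C#Cc3cnccc3O)CC[C@H]2C)c1` differs from compound 3 in one place: 4-hydroxypyridin-3-yl in place of 5-(hydroxymethyl)pyridin-3-yl on a triple-bonded carbon. Among the measured compounds shown here, the one measured step that alters the same ring without also changing the linker is a 4.7-fold lower number from compound 1 to compound 3 (0.67 log units; beyond the scatter), where one hydroxymethyl-bearing pyridine replaced another with a modest shift. The steps of a 50-fold lower number from compound 1 to compound 2 (1.70 log units; beyond the scatter) and an 11-fold higher number from compound 2 to compound 3 (1.03 log units; beyond the scatter) change linker and ring together and say little here. A step of modest size is therefore expected, in either direction, giving a 1.3-fold higher number from compound 3 to compound 4 (0.10 log units; within the scatter). Compound 4 is estimated at 40 nM, with a range from 10 nM to 160 nM.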

Compound 4, inhibition constant: 7.5 nM
The estimate for compound 4 lay 5.3-fold (0.73 log units) above the measured number; the measured number lies below the stated range.
By their numbers in this assay, from the lowest: compound 2; then compound 4; then compound 3; then compound 1.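

In this assay, 4-hydroxypyridin-3-yl on the triple-bonded carbon outperforms both hydroxymethyl pyridines, with a 4.3-fold lower number from compound 3 to compound 4 (0.63 log units; beyond the scatter) and a 20-fold lower number from compound 1 to compound 4 (1.30 log units; beyond the scatter), so this position tolerates a smaller group and rewards this swap. With the triple-bonded linker kept, the gap to the best compound narrows to a 2.5-fold higher number from compound 2 to compound 4 (0.40 log units; beyond the scatter), although that step changes linker and ring together. Nothing measured here explains the gain. As far as these compounds go, whether the hydroxyl itself matters stays open, and a methoxy group or an amine in its place would test that. Also open, from the compounds shown here alone, is how 4-hydroxypyridin-3-yl behaves on the ethenyl linker.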